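The source may hold more compounds than are shown below. What is called first, only, known or untested is meant among the compounds shown, and "the series" means these compounds.

In an ADME assay on cells (Fibroblast, Gallus gallus) for cytotoxicity, read by CCK-8 assay, with a stated time of 48 h (a lower number here means that less compound is tolerated, a higher number that more compound is tolerated), compound 1 (`CCc1ccc(CN[C@H]2CC(C(=O)O)=C[C@@H](OC(CC)CC)[C@@H]2NC(C)=O)cc1`) reads > 200000 nM as a limit, not a number. Compound 2 (`CCC(CC)O[C@@H]1C=C(C(=O)O)C[C@H](NCc2ccc(C(C)C)cc2)[C@H]1NC(C)=O`) reads > 200000 nM as a limit too. As far as these compounds go, compound 3 (`CCC(CC)O[C@@H]1C=C(C(=O)O)C[C@H](NCc2ccc(SC(C)CC)cc2)[C@H]1NC(C)=O`) also reads > 200000 nM as a limit, so its true value is unknown. Compound 4 (`CCC(CC)O[C@@H]1C=C(C(=O)O)C[C@H](NCc2ccc(-c3cc4ccccc4s3)cc2)[C@H]1NC(C)=O`) carries 1-benzothiophen-2-yl in place of (sec-butyl)sulfanyl on an aromatic carbon. The closest measured changes at that place are (a step that the two limits leave unreadable from compound 2 to compound 3) and (a step that the two limits leave unreadable from compound 1 to compound 3), and neither gives a size. All three compounds share one limit (the limit of > 200000 nM in this assay, at which 3 of the 3 values shown sit), which offers no trend to extend. In this assay only a small expected shift toward lower numbers, if any, is therefore assumed (an at least 1.1-fold lower number from compound 3 to compound 4 (0.07 log units; that floor lies within the scatter)). For compound 4 the estimate is 170000 nM with 60000 nM to 400000 nM as the expected range.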

Compound 4, half-maximal cytotoxic concentration: > 200000 nM
Compound 4: only a limit was reported (the forecaster's own chance of this, stated with the estimate: 65%); middle value at least 1.1-fold (0.07 log units) from the limit.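

Compound 4, like compound 1, compound 2 and compound 3, is reported only as a limit, so no step among these four can be read: the limit of > 200000 nM in this assay, at which 4 of the 4 values shown sit.
As far as these compounds go, the true value of each compound in this assay stays open, as does whether these groups on the aromatic carbon differ there at all.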